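Changing the chain on compound 2

The source may report more compounds than this note shows. Statements on the series, on what has been measured and on what is new or still open speak of the compounds shown alone.

Values in a functional assay on MDA-MB-231 cells (Homo sapiens) for antiproliferative activity, read by MTT assay; a lower number here means a stronger inhibitor, a higher number a weaker inhibitor:
- compound 1 `CCCCC/C=C\C/C=C\CCCCCCCc1cc(=O)c2c(O)cc(O)c(C)c2o1`: 6790 nM
- compound 2 `CCCC/C=C\CCCCCCCCCc1cc(=O)c2c(O)c(C)c(O)c(C)c2o1`: > 87000 nM, a limit
- compound 3 `CCCC/C=C\CCCCCCCCCc1cc(=O)c2c(O)c(C)c(O)cc2o1`: 42800 nM

Compound 2 stands only at a limit, > 87000 nM. Compound 4 `CCCCC/C=C\C/C=C\CCCCCCCc1cc(=O)c2c(O)c(C)c(O)c(C)c2o1` keeps the core of compound 2 and changes the chain: deca-1,4-dien-1-yl in place of oct-3-en-1-yl on a saturated chain carbon, seven bonds along the chain from an aromatic carbon. Among the measured compounds shown here, the one measured step, an at least 2.0-fold lower number from compound 2 to compound 3 (0.30 log units; that floor lies within the scatter), concerns a methyl on the core, not the chain. For the measured compounds named here, no measured step isolates the chain. The chain of compound 4 also occurs in compound 1, which gives 6790 nM, a lower number than compound 3 at 42800 nM. Those two also differ on the core. A lower number is therefore expected in this assay, with an estimated at least 2.9-fold lower number from compound 2 to compound 4 (0.46 log units; beyond the scatter). For compound 4 the estimate is 30000 nM, with an expected range of 10000 nM to 90000 nM.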

Compound 4, half-maximal inhibitory concentration: 16100 nM
Beside the measured number, compound 4's estimate is 1.9-fold (0.27 log units) above it; the measured number falls inside the stated range.
By their numbers in this assay, from the lowest: compound 1; then compound 4; then compound 3. At a limit, above all of these: compound 2.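

In this assay, deca-1,4-dien-1-yl in place of oct-3-en-1-yl gives an at least 5.4-fold lower number from compound 2 to compound 4 (0.73 log units; beyond the scatter), so a change in the chain alone moves the number beyond the scatter, and this step rests on a limit for compound 2. On the core, methyl in place of hydrogen on an aromatic carbon gives a 2.4-fold higher number from compound 1 to compound 4 (0.37 log units; beyond the scatter), a step with exact values at both ends. The core change can now be compared on two chains: the same change on two cores in this assay, an at least 2.0-fold lower number (0.30 log units; that floor lies within the scatter) from compound 2 to compound 3 and a 2.4-fold lower number (0.37 log units; beyond the scatter) from compound 4 to compound 1; the limit leaves it open whether they differ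

The compounds shown do not separate the added chain length from the second double bond. On these data alone, whether a longer saturated chain, or a chain ending in a carboxylic acid, would give a lower number remains open.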